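Amine substitution on the shared core: compound 2 to compound 3

This account rests on a few compounds, and the source may have more. Where it says the series, first, only, none or still open, it means among the compounds named here.

In a functional assay with Mus musculus as the target (a lower number here means a stronger inhibitor, a higher number a weaker inhibitor), compound 1 `NC1CCCc2onc(O)c21` gives 883000 nM. Compound 2 `OCCNC1CCCc2onc(O)c21` gives > 1000000 nM, which is a limit of the assay and not a number. Its true position is therefore unknown.

Compound 3 `CN(C)C1CCCc2onc(O)c21` carries dimethylamino in place of (2-hydroxyethyl)amino on a saturated ring carbon of a six-membered non-aromatic ring of carbon only: dimethylamino in place of (2-hydroxyethyl)amino on a saturated ring carbon.

Going by the values given here, one measured step bears on this change, also at the amine nitrogen: an at least 1.1-fold higher number from compound 1 to compound 2 (0.05 log units; that floor lies within the scatter). That step is open-ended and gives no firm size or direction for a further change at this nitrogen. Compound 3 also has no hydroxyethyl group, so compound 1 at 883000 nM is the only numerical anchor. No step beyond the scatter is therefore expected in this assay, and compound 3 may itself return only a limit. The expected change is an at least 1.1-fold lower number from compound 2 to compound 3 (0.04 log units; that floor lies within the scatter). Compound 3 is expected at 900000 nM, with an estimated range of 400000 nM to 2000000 nM.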

Compound 3, half-maximal inhibitory concentration: > 1000000 nM
Compound 3 ended at the assay's limit (the forecaster's own chance of this, stated with the estimate: 45%); at least 1.1-fold (0.04 log units) between middle value and limit.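

In this assay compound 3 gives > 1000000 nM, which is a limit of the assay and not a number. Dimethylamino in place of amino gives an at least 1.1-fold higher number from compound 1 to compound 3 (0.05 log units; that floor lies within the scatter), so this second substitution at the amine nitrogen, which carries no hydroxyethyl group, also yields no value inside the assay's range and only an open-ended step. The swap of (2-hydroxyethyl)amino for dimethylamino cannot be read, as both of its ends are limits, and the series now has two differently substituted amines at the same ceiling: the limit of > 1000000 nM in this assay, at which 2 of the 3 values shown sit.

From the compounds shown here alone, whether compound 2 and compound 3 truly differ remains open, as does the true size of each step away from compound 1, and so does whether any change at this nitrogen moves the number beyond the scatter in either direction. Also open, going by these compounds, is where methylamino, a longer alkyl chain such as butylamino, an acetamide or a carboxylic acid at the end of the chain would fall in this assay.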